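A few compounds are considered here, and "the series" means these few. Any claim that something is new, unique, unknown or untested is made for them only; others in the source may bear on it.

Series notes. Going by the values given here, compound 1 `O=C1O[C@H]([C@@H](O)Cn2cc(-c3ccc(Br)cc3)nn2)C(OCc2ccccc2)=C1OCc1ccccc1` is the reference point; in a functional assay on CFPAC-1 cells (Homo sapiens) for antiproliferative activity, read by MTT assay, with a stated time of 72 h (on this read-out lower numbers stand for stronger inhibition and higher numbers for weaker inhibition), compound 1 gives 5830 nM, the lowest of the three numbers measured so far. Compound 2 `O=C1O[C@H]([C@@H](O)Cn2cc(C3CC3)nn2)C(OCc2ccccc2)=C1OCc1ccccc1` gives 47700 nM, and compound 3 `O=C1O[C@H]([C@@H](O)Cn2cc(CNS(=O)(=O)c3ccc(Cl)cc3)nn2)C(OCc2ccccc2)=C1OCc1ccccc1` gives 38900 nM. Both replacements on the aromatic carbon weaken the series: an 8.2-fold higher number from compound 1 to compound 2 (0.91 log units; beyond the scatter) and a 6.7-fold higher number from compound 1 to compound 3 (0.82 log units; beyond the scatter), whereas a 1.2-fold lower number from compound 2 to compound 3 (0.09 log units; within the scatter). Compound 4 `Cc1ccc(S(=O)(=O)NCc2cn(C[C@H](O)[C@H]3OC(=O)C(OCc4ccccc4)=C3OCc3ccccc3)nn2)cc1` carries the change ((((4-methylphenyl)sulfonyl)amino)methyl in place of 4-bromophenyl on an aromatic carbon). Among the compounds with values here, compound 4 keeps the sulfonylaminomethyl arrangement of compound 3 with a 4-methylphenyl in place of the 4-chlorophenyl, a swap for which no measured step exists. The step is therefore expected to resemble a 6.7-fold higher number from compound 1 to compound 3 (0.82 log units; beyond the scatter), giving an estimated 6.0-fold higher number from compound 1 to compound 4 (0.78 log units; beyond the scatter). For compound 4 the estimate in this assay is 35000 nM, with a range from 15000 nM to 80000 nM.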

Compound 4, half-maximal inhibitory concentration: 68000 nM
Compound 4: the middle estimate sits 1.9-fold (0.29 log units) below what was measured; the measured number falls inside the stated range.
By their numbers in this assay, from the lowest: compound 1; then compounds 3, 2 and 4 (each within the scatter of the next).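

With a second sulfonylaminomethyl group on the aromatic carbon, the gap to the 4-bromophenyl of compound 1 persists (a 12-fold higher number from compound 1 to compound 4 (1.07 log units; beyond the scatter)), so it does not depend on the chloro substituent of compound 3. Methyl in place of chloro gives only a difference within the scatter (a 1.7-fold higher number from compound 3 to compound 4 (0.24 log units; within the scatter)). The sulfonylaminomethyl group also remains within the scatter of cyclopropyl (a 1.4-fold higher number from compound 2 to compound 4 (0.15 log units; within the scatter)). Open, going by these compounds, is whether an amine or a carboxylic acid in place of that methyl, or a 4-methoxyphenyl in place of 4-bromophenyl, would separate from these values. No measurement at hand bears on the cause of these steps.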